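This account rests on a few compounds, and the source may have more. Where it says the series, first, only, none or still open, it means among the compounds named here.

Measured in a functional assay on BXPC-3 cells (Homo sapiens) for antiproliferative activity, read by sulforhodamine B assay, with a stated time of 72 h (on this read-out higher numbers stand for weaker inhibition and lower numbers for stronger inhibition), so far
Compound 1 `CC(C)(C)c1[nH]cnc1/C=c1\[nH]c(=O)/c(=C/c2cccc(C(=O)N3CCCCC3)c2)[nH]c1=O` gives 100 nM as a number
Compound 2 `O=C(c1cccc(/C=c2\[nH]c(=O)/c(=C/c3ccccn3)[nH]c2=O)c1)N1CCC1` gives > 500 nM as a limit

Compound 2 is known only through the limit > 500 nM and so stands at the limit of > 500 nM in this assay, at which 1 of the 2 values shown sits, here. Compound 3 `O=C(c1cccc(/C=c2\[nH]c(=O)/c(=C/c3ccccn3)[nH]c2=O)c1)N1CCCCC1` is compound 2 with piperidin-1-yl in place of azetidin-1-yl on a carbonyl carbon, counted as piperidin-1-yl in place of azetidin-1-yl on a carbonyl carbon and otherwise unchanged. Among the measured compounds shown here, no measured pair isolates this change, so the expectation is loose. In this assay a modest shift toward stronger inhibition is expected, resting only on compound 1 reaching 100 nM as a number. The estimated move is an at least 1.2-fold lower number from compound 2 to compound 3 (0.09 log units; that floor lies within the scatter) and may be small, and compound 3 could also end up reported only as a limit. Compound 3 is expected at 400 nM on this estimate, within an estimated range from 120 nM to 1300 nM in this read-out.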

Compound 3, half-maximal inhibitory concentration in the BXPC-3 assay: > 500 nM
Compound 3: only a limit was reported; the forecaster's own chance of this, stated with the estimate: 40%; at least 1.2-fold (0.09 log units) between middle value and limit.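

In the BXPC-3 assay the step from azetidin-1-yl to piperidin-1-yl on the carbonyl carbon cannot be read, since compound 2 and compound 3 both rest on a limit rather than a number: the limit of > 500 nM in the BXPC-3 assay, at which 2 of the 3 values shown sit. With the piperidin-1-yl amide held fixed, pyridin-2-yl in place of 5-(tert-butyl)-1H-imidazol-4-yl gives an at least 5.0-fold higher number from compound 1 to compound 3 (0.69 log units; beyond the scatter), so the group on the double-bonded chain carbon matters in this read-out. In a physicochemical assay for solubility, read by HPLC, with a stated time of 24 h (a higher number here means a more soluble compound, a lower number a less soluble compound), the change on the carbonyl carbon does register, with an at least 6.6-fold lower number from compound 2 to compound 3 (0.82 log units; beyond the scatter). In the physicochemical assay compound 2 gives 0.662 ug/mL. In the physicochemical assay compound 3 gives < 0.1 ug/mL, which is itself a limit: the limit of < 0.1 ug/mL in the physicochemical assay, at which 1 of the 2 values shown sits.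

As far as these compounds go, how compound 2 and compound 3 rank in the BXPC-3 assay stays open. So does whether morpholin-4-yl on the carbonyl carbon would give a number in the BXPC-3 assay and a measurable value in the physicochemical assay.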